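The compounds below may be only part of what the source reports. "The series", "measured", "known", "first", "only" and "open" are said of these compounds alone.

Working notes on the series. Compound 3 `CN(C)c1ccc(/C=C2\S/C(=N\c3nc(-c4ccc(Cl)cc4)cs3)NC2=O)cc1` gives 300 nM in a functional assay on MDA-MB-231 cells (Homo sapiens) for cytotoxicity, read by MTT assay, with a stated time of 72 h (on this read-out lower numbers stand for stronger inhibition and higher numbers for weaker inhibition), and compound 1 `COc1ccc(/C=C2\S/C(=N\c3csc(-c4ccc(Cl)cc4)c3)NC2=O)cc1OC` gives 1900 nM in the same this assay, so compound 3 stands at the lower of the two numbers recorded, and the gap to compound 1 lies beyond the usual scatter. For compound 2 `COc1cccc(N2C(=O)CS/C2=N\c2csc(C3CC=Cc4ccccc43)c2C2CC=Cc3ccccc32)c1` the entry in this assay reads "not determined" (no result reported), no result having been reported, so it gives no bearing here.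

The next entry is compound 4 `O=C1N/C(=N/c2nc(-c3ccc(Cl)cc3)cs2)S/C1=C\c1ccc(F)cc1`, to be measured in this assay. It differs from compound 3 only in one place: fluoro in place of dimethylamino on an aromatic carbon. For the measured compounds named here, no measured pair isolates this change, so there is no step to lean on; compound 1 carries other groups on that ring but also differs at the core attachment, and its weaker number cannot be read as a guide to this single change.

With so thin a basis, the step from compound 3 to compound 4 in this assay is expected to be a modest loss, a 3.0-fold higher number from compound 3 to compound 4 (0.48 log units; beyond the scatter), larger than the scatter but not by much. For compound 4 the expected value in this assay is 900 nM, within a range of 300 nM to 3000 nM.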

Compound 4, half-maximal inhibitory concentration: > 50000 nM
Compound 4: no number, only a limit; the forecaster's own chance of this, stated with the estimate: 10%; middle value at least 55-fold (1.74 log units) away from the limit.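

In this assay compound 4 gives > 50000 nM, which is a limit of the assay and not a number. For the compounds shown here, with the rest of the structure held fixed, the single change of fluoro in place of dimethylamino on an aromatic carbon, para to a large group, brings an at least 160-fold higher number from compound 3 to compound 4 (2.22 log units; beyond the scatter), so the group at this position matters greatly, which compound 1 could not show, as it also differs at the core attachment. The size of this step is bounded on one side only: the limit of > 50000 nM in this assay, at which 1 of the 4 values shown sits.

As far as these compounds go, this is a single pair, so it remains open whether the number of compound 3 belongs to dimethylamino alone or would be kept by another amine, such as methylamino or morpholine, at this position. From the compounds shown here alone, it is also open whether a hydroxyl there would fall nearer compound 3 or compound 4.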